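A few compounds are considered here, and "the series" means these few. Any claim that something is new, unique, unknown or untested is made for them only; others in the source may bear on it.

Measured in a functional assay on A-375 cells (Homo sapiens) for inhibition, read by sulforhodamine B assay, with a stated time of 6 days; a higher number here means a weaker inhibitor, a lower number a stronger inhibitor:
Compound 1 `CNCCNCc1cccc(-c2nc(NC3CCOCC3)c(C)c(-c3cncnc3)n2)c1`: > 50000 nM (a limit)
Compound 2 `CNCCNCc1cccc(-c2nc(NC3CCOCC3)c(C)c(-c3c(C)nn(C)c3C)n2)c1`: > 50000 nM (a limit)
Compound 3 `CNCCNCc1cccc(-c2nc(NC3CCOCC3)c(C)c(-c3cccnc3)n2)c1`: 45500 nM

Compound 3 is the only one of these with an actual number, and it is a weak one at 45500 nM. Compound 1 and compound 2 stand at the limit of > 50000 nM in this assay, at which 2 of the 3 values shown sit.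

Compound 4 `CNCCNCc1cccc(-c2nc(NC3CCOCC3)c(C)c(-c3ccc(O)cc3)n2)c1` keeps the shared core and changes one group: 4-hydroxyphenyl in place of pyridin-3-yl on an aromatic carbon. In words, 4-hydroxyphenyl sits in place of pyridin-3-yl on an aromatic carbon.

Two measured steps end in the pyridin-3-yl group at this same place. One is an at least 1.0-fold lower number from compound 1 to compound 3 (0.04 log units; that floor lies within the scatter), and the other is an at least 1.0-fold lower number from compound 2 to compound 3 (0.04 log units; that floor lies within the scatter). The third step is a step that the two limits leave unreadable from compound 1 to compound 2. None of these gives a readable size beyond the scatter, and none of them involves 4-hydroxyphenyl, so in this assay no clear direction can be expected. The estimated change is small: a 1.5-fold lower number from compound 3 to compound 4 (0.18 log units; within the scatter). A result reported only as the limit is also expected to be quite possible. For compound 4 the estimate is 30000 nM, with an expected range of 8000 nM to 50000 nM.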

Compound 4, half-maximal inhibitory concentration: 24100 nM
For compound 4 the middle estimate is 1.2-fold (0.10 log units) above the measured one, and the stated range covers the measured number.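

In this assay, for the compounds shown here, 4-hydroxyphenyl gives the first steps at this position that are readable beyond the scatter: an at least 2.0-fold lower number from compound 2 to compound 4 (0.31 log units; beyond the scatter) and an at least 2.0-fold lower number from compound 1 to compound 4 (0.31 log units; beyond the scatter). Both sizes are only floors, and the true gaps could be larger, because compound 1 and compound 2 sit at a limit and not at a number: the limit of > 50000 nM in this assay, at which 2 of the 4 values shown sit.

Against pyridin-3-yl the result is less clear: a 1.9-fold lower number from compound 3 to compound 4 (0.28 log units; within the scatter), so these two groups cannot be told apart at this position.

The compounds shown leave open whether the hydroxy group matters or the carbon-only ring that carries it, and plain phenyl, 4-methoxyphenyl or 4-aminophenyl at this place would separate the two. Also open, going by these compounds, is whether any group here can bring the number far below the weak range seen so far.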